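Swapping the pyridine substituent on the glucagon antagonist core

The source may report more compounds than this note shows. Statements on the series, on what has been measured and on what is new or still open speak of the compounds shown alone.

Measured so far:
compound 1 `CC(C)(C)CC[C@H](c1ccc(C(=O)NCc2nn[nH]n2)cc1)N1C(=O)C(c2cncc(Cl)c2)=N[C@]12CC[C@@H](C(C)(C)C)CC2`: 480 nM
compound 2 `CC1(CC[C@H](c2ccc(C(=O)NCc3nn[nH]n3)cc2)N2C(=O)C(c3cc(Cl)cc(Cl)c3)=N[C@]23CC[C@@H](C(C)(C)C)CC3)CC1`: 100 nM

In a functional assay on CHO cells for antagonist activity at Glucagon receptor (Homo sapiens), read by cAMP accumulation, with stated times of 30 min and 45 min (on this read-out lower numbers stand for stronger inhibition and higher numbers for weaker inhibition), compound 1 gives 480 nM, the higher of the two numbers; compound 2 gives 100 nM, and that gap lies beyond the scatter. Compound 3 `CC(C)(C)CC[C@H](c1ccc(C(=O)NCc2nn[nH]n2)cc1)N1C(=O)C(c2cnccc2C(F)(F)F)=N[C@]12CC[C@@H](C(C)(C)C)CC2` keeps the core of compound 1 and carries 4-(trifluoromethyl)pyridin-3-yl in place of 5-chloropyridin-3-yl on a carbon with a double bond to nitrogen. For the measured compounds named here, only two compounds are known and none differs from another in a single place, so no measured step guides this change. The step from compound 1 to compound 3 is expected to be small, a 1.0-fold higher number from compound 1 to compound 3 (0.02 log units; within the scatter), not beyond the scatter in either direction. Compound 3 is therefore estimated at 500 nM, within 150 nM to 1600 nM.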

Compound 3, half-maximal inhibitory concentration: 1200 nM
The estimate for compound 3 lay 2.4-fold (0.38 log units) below the measured number; the measured number falls inside the stated range.
By their numbers in this assay, from the lowest: compound 2; then compound 1; then compound 3.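

Moving from 5-chloropyridin-3-yl to 4-(trifluoromethyl)pyridin-3-yl gives the first single-place step in this assay, a 2.5-fold higher number from compound 1 to compound 3 (0.40 log units; beyond the scatter), so this position responds to a change of pyridine substituent even though the pyridine ring itself is kept. Nothing measured here accounts for that loss. Still open, from the compounds shown here alone, is how this position would respond to a pyridin-3-yl carrying an amine or a nitrile, or to one with no substituent at all. The compounds shown also do not tell whether the same swap would cost as much on other side chains.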